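Adding one carbon to the side chain of compound 2

The source may hold more compounds than are shown below. What is called first, only, known or untested is meant among the compounds shown, and "the series" means these compounds.

Compound 1 `CCCSc1nc(N)nc2c1ncn2/C=C1/CC1(CO)CO`: > 20000 nM
Compound 2 `CCCNc1nc(N)nc2c1ncn2/C=C1/CC1(CO)CO`: "not determined" (no result reported)

In an ADME assay on MOLT-3 cells (Homo sapiens) for cytotoxicity, with a stated time of 7 days (a higher number here means that more compound is tolerated, a lower number that less compound is tolerated), compound 1 gives only > 20000 nM, which is a limit of the assay rather than a number. Compound 2 has no result here; its entry reads "not determined" (no result reported), so it stands on no number at all. Compound 3 `CCCCNc1nc(N)nc2c1ncn2/C=C1/CC1(CO)CO` differs from compound 2 by methyl in place of hydrogen on a saturated chain carbon, three bonds along the chain from a nitrogen on an aromatic ring. Among the measured compounds shown here, with no measured step to go on, no change beyond the usual scatter is expected in this assay. Given (the limit of > 20000 nM in this assay, at which 1 of the 2 values shown sits), compound 3 is estimated at 20000 nM, within 8000 nM to 50000 nM.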

Compound 3, half-maximal cytotoxic concentration: > 20000 nM
Compound 3 was reported as a limit; the forecaster's own chance of this, stated with the estimate: 70%; the middle value lies on the limit itself.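

In this assay compound 3 gives > 20000 nM, which is a limit and not a number. Among the compounds shown here, compound 1 also stands at a limit, so no step between compound 1 and compound 3 can be read. Left open is how much of either compound the cells tolerate.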